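The source may report more compounds than this note shows. Statements on the series, on what has been measured and on what is new or still open speak of the compounds shown alone.

Measured so far:
- Compound 1 `C=CC(=O)Nc1cc(Nc2nccc(NC(=O)c3cccc4ccccc34)n2)c(OC)cc1N1CCN(C)CC1`: 10600 nM
- Compound 2 `C=CC(=O)Nc1cc(Nc2nccc(NC(=O)c3cccc(OC)c3)n2)c(OC)cc1N1CCN(C)CC1`: 15900 nM

In a functional assay on NCI-H23 cells (Homo sapiens) for antiproliferative activity, read by MTT assay, with a stated time of 72 h (on this read-out lower numbers stand for stronger inhibition and higher numbers for weaker inhibition), compound 2 gives 15900 nM. Among the compounds with values here, with only two numbers to compare, it cannot be told apart from compound 1, as the step between them shows: a 1.5-fold higher number from compound 1 to compound 2 (0.18 log units; within the scatter).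

Compound 3 `C=CC(=O)Nc1cc(Nc2nccc(NC(=O)c3ccc(C(F)(F)F)cc3)n2)c(OC)cc1N1CCN(C)CC1` keeps the shared core and alters one group: 4-(trifluoromethyl)phenyl in place of 3-methoxyphenyl on a carbonyl carbon. In words, this is 4-(trifluoromethyl)phenyl in place of 3-methoxyphenyl on a carbonyl carbon.

Within the data shown here, only one measured step bears on this change, a swap at the same carbonyl carbon: a 1.5-fold higher number from compound 1 to compound 2 (0.18 log units; within the scatter). Among the measured compounds shown here, one step is thin evidence, and no measured compound carries a trifluoromethyl group. No step beyond the scatter is therefore expected in this assay, in either direction.

The expected step is a 1.3-fold lower number from compound 2 to compound 3 (0.12 log units; within the scatter). For compound 3 the estimated value is 12000 nM, with an expected range of 5000 nM to 28000 nM.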

Compound 3, half-maximal inhibitory concentration: 9200 nM
Compound 3: the middle estimate sits 1.3-fold (0.12 log units) above what was measured; the measured number falls inside the stated range.
By their numbers in this assay, from the lowest: compounds 3, 1 and 2 (each within the scatter of the next).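

In this assay, a third aromatic group on this carbonyl carbon again produces no step beyond the scatter: the change gives a 1.7-fold lower number from compound 2 to compound 3 (0.24 log units; within the scatter), and the comparison with the naphthalen-1-yl compound gives a 1.2-fold lower number from compound 1 to compound 3 (0.06 log units; within the scatter). Compounds 1, 2 and 3 therefore cannot be told apart, even though 4-(trifluoromethyl)phenyl has 0 hydrogen-bond acceptors and 3-methoxyphenyl has 1, so this difference in count has no readable effect across this pair. No other measurement here bears on why these numbers stay so close.

From the compounds shown here alone, it remains open whether a non-aromatic group on this carbonyl carbon, such as a short alkyl chain, or an aromatic ring carrying an amine or a carboxylic acid, would give a step beyond the scatter. These compounds also leave open whether the same holds when the shared core is changed elsewhere.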